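The compounds below may be only part of what the source reports. "The series", "measured", "known", "first", "only" and "open" are said of these compounds alone.

Compound 2 `O=C(Nc1cccc(-n2cc(-c3ccncc3)c(-c3cc(O)cc(Cl)c3)n2)c1)Nc1ccc(Cl)c(Cl)c1` is the starting point. In a functional assay on MOLT-4 cells (Homo sapiens) for inhibition, read by sulforhodamine B assay, with a stated time of 48 h, tested at 0.1 uM (a higher number here means a weaker effect of the compound at the concentration tested, a lower number a stronger effect), compound 2 gives 94%. Among the compounds with values here, its two measured neighbours sit within the usual scatter of that number: compound 1 `O=C(Nc1cccc(-n2cc(-c3ccncc3)c(-c3cc(O)cc(Cl)c3)n2)c1)Nc1ccc(Cl)c(C(F)(F)F)c1` gives 92%, and the one step that connects these two, a number 2 percentage points higher from compound 1 to compound 2 (within the scatter), concerns the chloro in place of trifluoromethyl on an aromatic carbon. Compound 3 `COc1cc(Cl)cc(-c2nn(-c3cccc(NC(=O)Nc4cc(C(F)(F)F)cc(C(F)(F)F)c4)c3)cc2-c2ccncc2)c1`, which carries a methoxy and a different pair of groups on its outer ring, gives 87%.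

Compound 4 `COc1cc(Cl)cc(-c2nn(-c3cccc(NC(=O)Nc4ccc(Cl)c(Cl)c4)c3)cc2-c2ccncc2)c1` differs from compound 2 in one place: methyl in place of hydrogen on an oxygen on an aromatic ring. Within the data shown here, no measured step matches this change directly. Among the measured compounds shown here, the only measured step, from compound 1 to compound 2, touches a different part of the molecule and stays within the scatter, and compound 3, the one methoxy-bearing compound, differs from compound 1 in more than one place, so its value can only be read as a rough hint that a methoxy does not move the number far.

The step expected from compound 2 to compound 4 is therefore a number 4 percentage points lower from compound 2 to compound 4 (within the scatter), nothing beyond the scatter. Compound 4 is estimated to give 90%, with a likely range from 78% to 99%.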

Compound 4, a percentage reported as activity, at one concentration (the size of the read-out at that concentration, not a potency): 88%
Estimate against measurement, compound 4: 2 percentage points above, and the stated range covers the measured number.
By their numbers in this assay, from the lowest: compounds 3, 4, 1 and 2 (each within the scatter of the next).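

Within the data shown here, compound 4 gives the first direct reading of this change. In this assay, going from hydroxy to methoxy on the aromatic ring gives a number 6 percentage points lower from compound 2 to compound 4 (within the scatter), so among these two compounds the hydrogen on this oxygen can be replaced by methyl without a change beyond the scatter. Nothing available explains this result or links it to any property of either group.

The compounds shown leave open whether a longer chain on this oxygen, such as ethoxy, would also stay within the scatter. They also leave open what an amine or a carboxylic acid in place of the hydroxy would do to this read-out.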